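A few compounds are considered here, and "the series" means these few. Any claim that something is new, unique, unknown or untested is made for them only; others in the source may bear on it.

Measured so far:
Compound 1, `N=C(NN)c1cn([C@@H]2O[C@H](CO)[C@@H](O)[C@H]2O)c2nnnc(N)c12`: 3000 nM
Compound 2, `N/C(=N\O)c1cn([C@@H]2O[C@H](CO)[C@@H](O)[C@H]2O)c2nnnc(N)c12`: 1500 nM
Compound 3, `NC(=O)c1cn([C@@H]2O[C@H](COC(=O)c3ccccc3)[C@@H](OC(=O)c3ccccc3)[C@H]2OC(=O)c2ccccc2)c(N)c1C(N)=O`: a limit, > 10000 nM

In a functional assay on KB cells (Homo sapiens) for inhibition (a lower number here means a stronger inhibitor, a higher number a weaker inhibitor), compound 2 gives 1500 nM, the lowest of the two numbers shown; its nearest neighbour is compound 1, and the change a 2.0-fold lower number from compound 1 to compound 2 (0.30 log units; within the scatter) stays inside the usual scatter. Compound 3 gives only a limit, (the limit of > 10000 nM in this assay, at which 1 of the 3 values shown sits). Compound 4, `NC(=O)c1cn([C@@H]2O[C@H](CO)[C@@H](O)[C@H]2O)c2nnnc(N)c12`, differs from compound 2 by a group of 3 heavy atoms (1 carbon, 1 nitrogen, 1 oxygen; no ring) in place of a group of 4 heavy atoms (1 carbon, 2 nitrogen, 1 oxygen; no ring), on an aromatic carbon, with a carbamoyl entering. For the measured compounds named here, the only measured step that bears on this kind of change on the same aromatic carbon is the one from compound 1 to compound 2, and it was too small to count. No movement beyond the scatter is therefore expected. Compound 4 is estimated at 1500 nM, with a range from 500 nM to 5000 nM. This corresponds to an expected step of no change at the digits printed from compound 2 to compound 4 (within the scatter).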

Compound 4, half-maximal inhibitory concentration: 80 nM
For compound 4 the middle estimate is 19-fold (1.27 log units) above the measured one; measured number outside the range, below it.
By their numbers in this assay, from the lowest: compound 4; then compounds 2 and 1 (each within the scatter of the next). At a limit, above all of these: compound 3.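

In this assay this aromatic carbon proves sensitive to the group it carries: carbamoyl brings a 19-fold lower number from compound 2 to compound 4 (1.27 log units; beyond the scatter) and also a 38-fold lower number from compound 1 to compound 4 (1.57 log units; beyond the scatter) while the earlier swap between the two larger groups stayed within the scatter. The position therefore tolerates some changes with little effect, yet responds strongly to this one. Nothing given here accounts for the size of these steps. On these data alone, whether a carboxylic acid or a nitrile on the same carbon would match carbamoyl remains open. So does whether a methyl group on the amide nitrogen would keep this strength.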